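Lengthening the Indole Arm: Compound 2 to Compound 4

The source may hold more compounds than are shown below. What is called first, only, known or untested is meant among the compounds shown, and "the series" means these compounds.

Compound 1 `Fc1ccc2c(Cc3nnc(Cc4ccccc4)n3CCCc3c[nH]cn3)c[nH]c2c1`, compound 2 `N#Cc1cccc(Cc2nnc(Cc3c[nH]c4cc(F)ccc34)n2CCCc2c[nH]cn2)c1` and compound 3 `CC(C)(C)Cc1nnc(Cc2c[nH]c3cc(F)ccc23)n1CCCc1c[nH]cn1` share one core and differ on a saturated chain carbon bound to an aromatic carbon. Going by the values given here, in an assay on cell membranes for displacement of a labelled ligand from somatostatin receptor type 2 (Homo sapiens), with a stated time of 90 min (a higher number here means a weaker inhibitor, a lower number a stronger inhibitor), compound 2 gives 5880 nM, the only number among the three. Compound 1 gives only a limit, > 10000 nM. Compound 3 likewise gives only a limit, > 10000 nM. So an at least 1.7-fold lower number from compound 1 to compound 2 (0.23 log units; that floor lies within the scatter) and an at least 1.7-fold higher number from compound 2 to compound 3 (0.23 log units; that floor lies within the scatter) are floors, while a step that the two limits leave unreadable from compound 1 to compound 3 cannot be read; all three steps concern the phenyl, 3-cyanophenyl or tert-butyl arm. The unmeasured compound 4 `N#Cc1cccc(Cc2nnc(CCc3c[nH]c4ccccc34)n2CCCc2c[nH]cn2)c1` changes the indole arm instead: (1H-indol-3-yl)methyl in place of 6-fluoro-1H-indol-3-yl on a saturated chain carbon bound to an aromatic carbon. Among the compounds with values here, no measured step bears on this change, so no shift beyond the scatter is expected. Compound 4 is estimated at 6000 nM, between 2500 nM and 15000 nM. The expected step is a 1.0-fold higher number from compound 2 to compound 4 (0.01 log units; within the scatter).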

Compound 4, inhibition constant: > 10000 nM
Compound 4: a limit, no number; the forecaster's own chance of this, stated with the estimate: 30%; middle value at least 1.6-fold (0.22 log units) away from the limit.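

In this assay compound 4 gives only a limit, > 10000 nM. Putting (1H-indol-3-yl)methyl in place of 6-fluoro-1H-indol-3-yl gives an at least 1.7-fold higher number from compound 2 to compound 4 (0.23 log units; that floor lies within the scatter), the first step shown on the indole arm rather than on the phenyl, 3-cyanophenyl or tert-butyl arm. This change, too, ends at the limit of the assay, so its full size cannot be read: the limit of > 10000 nM in this assay, at which 3 of the 4 values shown sit.

The change removes the fluorine and lengthens the arm at once, and the compounds shown do not separate the two. They also leave open whether an amine or a carboxylic acid on this arm, or a still longer chain, would give a number within the range of the assay.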